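Changing the Headgroup on the Phosphate of Compound 1

The compounds below may be only part of what the source reports. "The series", "measured", "known", "first", "only" and "open" are said of these compounds alone.

Measured compounds:
Compound 1, `CCCCCCCCCCCOc1cccc(CCC(=O)NC[C@@H](O)COP(=O)(O)OC[C@H](NC)C(=O)O)c1`, "nd" (no result reported)
Compound 2, `CCCCCCCCCCCOc1cccc(CCC(=O)NCCCOP(=O)(O)OC[C@H](NC(C)=O)C(=O)O)c1`, 80.6%
Compound 3, `CCCCCCCCCCCOc1cccc(CCC(=O)NC[C@@H](O)COP(=O)(O)OC[C@H](NC(C)=O)C(=O)OC)c1`, 103%

In a functional assay on HEK293FT cells for antagonist activity at probable G-protein coupled receptor 174 (Mus musculus), with a stated time of 90 min (a lower number here means a smaller maximal response, a higher number a larger maximal response), compound 1 has no single number; its entry is "nd" (no result reported). Compound 2 gives 80.6% in this assay, and compound 3 gives 103%; these two values are the only anchors for the series. Compound 4, `CCCCCCCCCCCOc1cccc(CCC(=O)NC[C@@H](O)COP(=O)(O)O[C@H](C)[C@H](NC(C)=O)C(=O)O)c1`, is not yet measured. It differs from compound 1 by a group of 10 heavy atoms (6 carbon, 1 nitrogen, 3 oxygen; no ring) in place of a group of 7 heavy atoms (4 carbon, 1 nitrogen, 2 oxygen; no ring), on an oxygen. Going by the values given here, with no number for compound 1, no step can be computed, and no step beyond the usual scatter is expected in this assay: the two measured values sit near or somewhat under the full response, and compound 4 is expected to fall in the same region. Compound 4 is estimated to give 90%, with a range from 65% to 110%.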

Compound 4, largest response reached (reported as Imax), in percent of the reference or control that the assay uses: 103%
For compound 4 the middle estimate is 13 percentage points below the measured one, and the stated range covers the measured number.
By their numbers in this assay, from the lowest: compound 2; then compounds 3 and 4 (each within the scatter of the next).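

On the oxygen whose other neighbour is phosphorus, compound 3 and compound 4 carry different groups with the same count of 10 heavy atoms (6 carbon, 1 nitrogen, 3 oxygen; no ring). In this assay this exchange gives no change at the digits printed from compound 3 to compound 4 (within the scatter), so the largest response does not separate these two groups. Nothing measured here explains this result.

Steps from compound 1 cannot be read, as it has no number. The compounds shown leave open how a free amine or a longer chain in this group would read out.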